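This account rests on a few compounds, and the source may have more. Where it says the series, first, only, none or still open, it means among the compounds named here.

Measured in a functional assay on U-87MG ATCC cells (Homo sapiens) for inhibition, read by MTT assay, with a stated time of 72 h; on this read-out lower numbers stand for stronger inhibition and higher numbers for weaker inhibition:

compound 1, `COc1cc2c(Oc3ccc(NC(=O)c4nn(-c5cccc(F)c5)c(=O)cc4C)cc3F)ccnc2cc1OCCCN1CCCCC1`: 1500 nM
compound 2, `COc1cc2c(Oc3ccc(NC(=O)c4nn(-c5cccc(F)c5)c(=O)cc4C)cc3F)ccnc2cc1OCCCN1CCC(C)CC1`: 1800 nM
compound 3, `COc1cc2c(Oc3ccc(NC(=O)c4nn(-c5ccc(Cl)cc5)c(=O)cc4C)cc3F)ccnc2cc1OCCCN1CCCCC1`: 1400 nM

Compound 1 and compound 2 share the core of compound 1 and differ by methyl in place of hydrogen on a saturated ring carbon; the step is a 1.2-fold higher number from compound 1 to compound 2 (0.08 log units; within the scatter). Compound 3 differs from compound 1 in the core by 4-chlorophenyl in place of 3-fluorophenyl on an aromatic nitrogen; the step is a 1.1-fold lower number from compound 1 to compound 3 (0.03 log units; within the scatter). All three numbers sit close together, so no order among compound 1, compound 2 and compound 3 can be read from them.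

Compound 4, `COc1cc2c(Oc3ccc(NC(=O)c4nn(-c5ccc(Cl)cc5)c(=O)cc4C)cc3F)ccnc2cc1OCCCN1CCC(C)CC1`, is not yet measured. It differs from compound 3 by methyl in place of hydrogen on a saturated ring carbon. Among the compounds with values here, this is the same change as the one from compound 1 to compound 2, made on the core of compound 3 instead of the core of compound 1; the two places are described in the same words. Within the data shown here, for compound 4 the expected step is a 1.2-fold higher number from compound 3 to compound 4 (0.08 log units; within the scatter), resting on the one earlier instance, where the step from compound 1 to compound 2 stayed within the scatter. The expected value for compound 4 is 1700 nM, estimated to fall between 900 nM and 3200 nM.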

Compound 4, half-maximal inhibitory concentration: 1350 nM
For compound 4 the middle estimate is 1.3-fold (0.10 log units) above the measured one, within the range that was stated.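

In this assay, methyl in place of hydrogen on the core of compound 3 gives a 1.0-fold lower number from compound 3 to compound 4 (0.02 log units; within the scatter), and this step agrees with the earlier one: the same change on two cores in this assay, a 1.2-fold higher number (0.08 log units; within the scatter) from compound 1 to compound 2 and a 1.0-fold lower number (0.02 log units; within the scatter) from compound 3 to compound 4, 1.2-fold (0.09 log units) apart, within the scatter of two such steps. On the core of compound 2, 4-chlorophenyl in place of 3-fluorophenyl gives a 1.3-fold lower number from compound 2 to compound 4 (0.12 log units; within the scatter), and this step also agrees with its earlier instance: the same change on two cores in this assay, a 1.1-fold lower number (0.03 log units; within the scatter) from compound 1 to compound 3 and a 1.3-fold lower number (0.12 log units; within the scatter) from compound 2 to compound 4, 1.2-fold (0.09 log units) apart, within the scatter of two such steps. Within the data shown here, both changes therefore stay within the scatter on both cores, but steps this small show only that neither change produced a readable step here, not that an effect of real size would carry from one core to another.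

From the compounds shown here alone, whether morpholin-4-yl in place of piperidin-1-yl, or a different group such as 4-methoxyphenyl on the aromatic nitrogen, would give a step beyond the scatter remains open. Also open, going by these compounds, is whether any such step would hold its size on a second core.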